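Adding a 3-iodobenzyl group to the parent nucleoside

A few compounds are considered here, and "the series" means these few. Any claim that something is new, unique, unknown or untested is made for them only; others in the source may bear on it.

Compound 3 `Nc1ncnc2c1ncn2[C@@H]1OC[C@](O)(CO)[C@H]1O` has the lowest number of the three measured compounds in an assay on CHO cells for displacement of a labelled ligand from adenosine receptor A1 (Homo sapiens), tested at 10 uM (on this read-out lower numbers stand for less inhibition and higher numbers for more inhibition at the one concentration tested (going by the name of the read-out)), giving 6%. Its nearest neighbour is compound 1 `OC[C@@]1(O)CO[C@@H](n2cnc3c(NCc4cccc(Cl)c4)ncnc32)[C@@H]1O`, which in this assay gives 10%, and the step of a number 4 percentage points lower from compound 1 to compound 3 (within the scatter) is within the scatter. The most distant is compound 2 `OC[C@]1(O)CO[C@@H](n2cnc3c(NCc4cccc(I)c4)ncnc32)[C@@H]1O`, which in this assay gives 35%, beyond the scatter from compound 3.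

Compound 4 `OC[C@@]1(O)CO[C@@H](n2cnc3c(NCc4cccc(I)c4)ncnc32)[C@@H]1O` differs from compound 3 by 3-iodobenzyl in place of hydrogen on a nitrogen on an aromatic ring. Going by the values given here, no measured step covers exactly this change, but two observations bear on it: the reverse of the small step of a number 4 percentage points lower from compound 1 to compound 3 (within the scatter) shows that placing 3-chlorobenzyl on that nitrogen shifts the number only within the scatter, while compound 2, which also bears 3-iodobenzyl, gives 35%. A modest rise is therefore expected, a number 11 percentage points higher from compound 3 to compound 4 (beyond the scatter), though it may well stay within the scatter. Compound 4 is estimated at 17% in this assay, within a range from 3% to 38%.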

Compound 4, a percentage reported as inhibition, at one concentration (the size of the read-out at that concentration, not a potency): 27%
Beside the measured number, compound 4's estimate is 10 percentage points below it; the range from low to high includes it.
By their numbers in this assay, from the lowest: compounds 3 and 1 (each within the scatter of the next); then compounds 4 and 2 (each within the scatter of the next).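

In this assay, 3-iodobenzyl on this nitrogen produces a clear rise where 3-chlorobenzyl did not, with a number 21 percentage points higher from compound 3 to compound 4 (beyond the scatter). The halogen on the benzyl group therefore matters at this position, with a number 17 percentage points higher from compound 1 to compound 4 (beyond the scatter). The two 3-iodobenzyl compounds stay within the scatter of each other despite the opposite drawn configuration at a saturated ring carbon, with a number 8 percentage points lower from compound 2 to compound 4 (within the scatter), and this comparison isolates that single feature: the fact that compounds 2 and 4 differ only in the configuration as drawn.

The compounds shown leave open whether an unsubstituted benzyl or a 3-bromobenzyl group on this nitrogen would read like the chloro or the iodo compound. They also leave open whether the configuration at that carbon is equally without consequence for a 3-chlorobenzyl compound, and single-concentration readings give no potency for any of them.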